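The source may hold more compounds than are shown below. What is called first, only, known or untested is meant among the compounds shown, and "the series" means these compounds.

Compound 1 `N#Cc1ccc(Nc2nc(Oc3ccnc4ccccc34)nc(N3CCN(c4ccccc4Cl)CC3)n2)cc1C(F)(F)F` gives in a functional assay on DU-145 cells (Homo sapiens) for cytotoxicity, read by sulforhodamine B assay, with a stated time of 48 h (a higher number here means a weaker inhibitor of growth, a lower number a stronger inhibitor of growth), only a limit, > 100000 nM.
Compound 2 `N#Cc1ccc(Nc2nc(Oc3ccnc4ccccc34)nc(N3CCN(c4ccccc4)CC3)n2)cc1C(F)(F)F` gives in this assay only a limit, > 100000 nM.
Compound 3 `N#Cc1ccc(Nc2nc(Oc3ccnc4ccccc34)nc(N3CCN(c4ccccc4F)CC3)n2)cc1C(F)(F)F` gives in this assay only a limit, > 100000 nM.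

The three compounds share one core and differ only in what sits on one aromatic carbon of the outer ring: chloro, hydrogen or fluoro. Compound 3 stands where the other two stand, at the reading of this assay at which all three values sit (the limit of > 100000 nM in this assay, at which 3 of the 3 values shown sit). Every value is a limit, not a number. For that reason none of the three steps can be sized: a step that the two limits leave unreadable from compound 1 to compound 2, a step that the two limits leave unreadable from compound 1 to compound 3 and a step that the two limits leave unreadable from compound 2 to compound 3 all remain unreadable.

Compound 4 `CC(=O)N1CCN(c2nc(Nc3ccc(C#N)c(C(F)(F)F)c3)nc(Oc3ccnc4ccccc34)n2)CC1` differs from compound 3 in one place: acetyl in place of 2-fluorophenyl on an amine nitrogen in a ring. This change is of a different kind from the three measured ones, which swapped only a single atom on an aromatic carbon. Those steps bear on the present one only in that the shared core, with three different groups in that outer position, never reached measurable growth inhibition. Among the measured compounds shown here, no measured step gives a direction. The step of a number no higher from compound 3 to compound 4 (the limit leaves the size open) is therefore expected to be none beyond the scatter. Compound 4 is estimated at 100000 nM, within a range from 30000 nM to 300000 nM.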

Compound 4, concentration for total growth inhibition: > 100000 nM
Compound 4: only a limit was reported; the forecaster's own chance of this, stated with the estimate: 80%; the middle value lies on the limit itself.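

Among the compounds shown here, compound 4 again gives only a limit, so no step among compound 1, compound 2, compound 3 and compound 4 can be read, all four sitting at one reading: the limit of > 100000 nM in this assay, at which 4 of the 4 values shown sit. The compounds shown leave open whether any group on that ring nitrogen of the shared core can give a measurable value in this assay.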